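A few compounds are considered here, and "the series" means these few. Any claim that something is new, unique, unknown or untested is made for them only; others in the source may bear on it.

Compound 1 `NC1CCC(Nc2nc(NCc3ccc(Br)cc3)c3ncn(C4CCCC4)c3n2)CC1` is the weaker of the two measured compounds: in a functional assay on K562 cells (Homo sapiens) for inhibition, with a stated time of 72 h (on this read-out lower numbers stand for stronger inhibition and higher numbers for weaker inhibition), compound 1 gives 1170 nM, while compound 2 `OC1CCC(Nc2nc(NCc3ccc(-c4ccco4)nc3)c3ncn(C4CCCC4)c3n2)CC1` gives 303 nM in this assay, a gap that lies beyond the scatter. Compound 3 `NC1CCC(Nc2nc(NCc3cc(Cl)ccc3O)c3ncn(C4CCCC4)c3n2)CC1` has not yet been measured in this assay. It differs from compound 1 in one place: 5-chloro-2-hydroxyphenyl in place of 4-bromophenyl on a saturated chain carbon bound to a nitrogen on an aromatic ring. Going by the values given here, with no measured step of this kind to lean on, the change is expected to shift the number only modestly, if at all, so the step of a 1.5-fold lower number from compound 1 to compound 3 (0.17 log units; within the scatter) is estimated to stay close to the scatter. Compound 3 is thus expected to give about 800 nM, within a range of 250 nM to 2500 nM.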

Compound 3, half-maximal inhibitory concentration: 690 nM
Compound 3: middle estimate off by 1.2-fold (0.06 log units), on the high side, within the range that was stated.
By their numbers in this assay, from the lowest: compound 2; then compounds 3 and 1 (each within the scatter of the next).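

On the saturated chain carbon bound to a nitrogen on an aromatic ring, 5-chloro-2-hydroxyphenyl in place of 4-bromophenyl gives a 1.7-fold lower number from compound 1 to compound 3 (0.23 log units; within the scatter) in this assay. The position thus takes a group with one hydrogen-bond donor and one acceptor, where the departing group has neither, without a shift beyond the scatter. No measured evidence bears on this result. Still open, going by these compounds, is whether the hydroxy group or the chlorine alone would read the same, and how an amine or a carboxylic acid on this phenyl ring would read in this assay.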